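Swapping Chloro for Methoxy on a Shared Core

The source may report more compounds than this note shows. Statements on the series, on what has been measured and on what is new or still open speak of the compounds shown alone.

In a functional assay on HCT-116 cells (Homo sapiens) for antiproliferative activity, read by MTT assay, with a stated time of 48 h (a lower number here means a stronger inhibitor, a higher number a weaker inhibitor), compound 1 `Cc1cnc(Nc2ccc(S(C)(=O)=O)cc2)nc1Nc1nc2ccccc2s1` gives 760 nM. Compound 2 `Cc1cnc(Nc2ccc(Cl)cc2)nc1Nc1nc2ccccc2s1` reaches only a limit in this assay, reported as > 50000 nM. The step of an at least 65-fold higher number from compound 1 to compound 2 (1.81 log units; beyond the scatter) is large, and compound 2 stands at the limit of > 50000 nM in this assay, at which 1 of the 2 values shown sits. Compound 3 `COc1ccc(Nc2ncc(C)c(Nc3nc4ccccc4s3)n2)cc1` carries the change (methoxy in place of chloro on an aromatic carbon), so methoxy brings one hydrogen-bond acceptor where chloro had none. Going by the values given here, only the step from compound 1 to compound 2 bears on this, and it was large; compound 3 is expected to recover part of that loss, an estimated step of an at least 3.3-fold lower number from compound 2 to compound 3 (0.52 log units; beyond the scatter). Compound 3 is therefore estimated at 15000 nM, within 3000 nM to 50000 nM.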

Compound 3, half-maximal inhibitory concentration: > 50000 nM
Compound 3 ended at the assay's limit; the forecaster's own chance of this, stated with the estimate: 35%; middle value at least 3.3-fold (0.52 log units) from the limit.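

Replacing methylsulfonyl with methoxy gives an at least 65-fold higher number from compound 1 to compound 3 (1.81 log units; beyond the scatter) in this assay. A hydrogen-bond acceptor on this aromatic carbon is therefore not enough on its own to recover a readable value, and among the compounds shown only methylsulfonyl gives one. Compound 2 and compound 3 both end at a limit, and the step between them cannot be read: the limit of > 50000 nM in this assay, at which 2 of the 3 values shown sit.

Going by these compounds, whether a sulfonamide or a carboxylic acid in the same place would give a readable value, as compound 1 does, stays open. On these data alone, how compound 2 and compound 3 truly rank against each other also stays open.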